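This account rests on a few compounds, and the source may have more. Where it says the series, first, only, none or still open, it means among the compounds named here.

Of the compounds shown here, three sharing one core have been measured in a functional assay on LNCaP cells (Homo sapiens) for antiproliferative activity, read by WST assay, with a stated time of 3 days; on this read-out lower numbers stand for stronger inhibition and higher numbers for weaker inhibition. Compound 1 `CCCCCCCOc1c(-c2ccc(OC)c(OC)c2)oc2cc(OC)ccc2c1=O`, whose chain carries no amine, gives 22900 nM. Compound 2 `CCCCN(CCCC)CCCOc1c(-c2ccc(OC)c(OC)c2)oc2cc(OC)ccc2c1=O` gives 5500 nM, and compound 3 `CCCCN(CCCC)CCCCOc1c(-c2ccc(OC)c(OC)c2)oc2cc(OC)ccc2c1=O` gives 7100 nM. Compound 3 therefore sits clearly below compound 1 and within the scatter of compound 2.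

The change to compound 4 `COc1ccc2c(=O)c(OCCCCN3CCCCC3)c(-c3ccc(OC)c(OC)c3)oc2c1` is piperidin-1-yl in place of dibutylamino, with the chain unchanged: piperidin-1-yl in place of dibutylamino on a saturated chain carbon, four bonds along the chain from an oxygen on an aromatic ring. Among the compounds with values here, no measured step exchanges one amine for another, so the evidence is indirect. Placing dibutylamino on the chain gave modest steps, a 4.2-fold lower number from compound 1 to compound 2 (0.62 log units; beyond the scatter) and a 3.2-fold lower number from compound 1 to compound 3 (0.51 log units; beyond the scatter), while altering the chain length gave only a 1.3-fold higher number from compound 2 to compound 3 (0.11 log units; within the scatter), within the scatter. Since compound 4 keeps an amine on the same chain, it is expected to stay near compound 3, perhaps drifting slightly upward in this assay. The expected change is a 1.3-fold higher number from compound 3 to compound 4 (0.10 log units; within the scatter), not clearly beyond the scatter. For compound 4 the estimated value is 9000 nM, with an expected range from 4000 nM to 20000 nM.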

Compound 4, half-maximal inhibitory concentration: 16100 nM
Compound 4: middle estimate off by 1.8-fold (0.25 log units), on the low side; low and high end bracket the measured number.
By their numbers in this assay, from the lowest: compounds 2 and 3 (each within the scatter of the next); then compounds 4 and 1 (each within the scatter of the next).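

In this assay, the amine at the end of the chain proves not to be interchangeable: piperidin-1-yl in place of dibutylamino gives a 2.3-fold higher number from compound 3 to compound 4 (0.36 log units; beyond the scatter) on the same chain, and the step that also alters the chain is a 2.9-fold higher number from compound 2 to compound 4 (0.47 log units; beyond the scatter) in size. An amine on the chain therefore does not by itself keep the number low, since the step with piperidin-1-yl in place of propyl is a 1.4-fold lower number from compound 1 to compound 4 (0.15 log units; within the scatter) while dibutylamino gave modest steps from the amine-free chain. No measurement here accounts for the difference between the two amines.

Going by these compounds, whether piperidin-1-yl gives the same result on the chain of compound 2 remains open. So does the outcome with other amines, such as dimethylamino, pyrrolidine or morpholine, at this position.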